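This account rests on a few compounds, and the source may have more. Where it says the series, first, only, none or still open, it means among the compounds named here.

Among the compounds with values here, compound 1 `CNC(=O)c1cc(Oc2ccc(NC(=O)c3nccc(-c4ccc(OC)cc4)n3)cc2)ccn1` is the only member of this small set with a numeric result: in a functional assay on PC-3 cells (Homo sapiens) for cytotoxicity, read by MTT assay, with a stated time of 72 h (a lower number here means a stronger inhibitor, a higher number a weaker inhibitor), compound 1 gives 14200 nM. Compound 2 `CNC(=O)c1cc(Oc2ccc(NC(=O)c3cc(-c4ccc(F)cc4)ncn3)cc2F)ccn1` reaches only a limit of the assay in this assay, recorded as > 100000 nM. Compound 3 `CNC(=O)c1cc(Oc2ccc(NC(=O)c3cc(-c4ccc(Cl)cc4)ncn3)cc2)ccn1` likewise stands at a limit in this assay, recorded as > 100000 nM. Within the data shown here, both of those rest on (the limit of > 100000 nM in this assay, at which 2 of the 3 values shown sit), so compound 1 is the single point from which a number can be compared, and no two measured compounds here differ in only one place.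

Compound 4 `CNC(=O)c1cc(Oc2ccc(NC(=O)c3nccc(-c4ccccc4)n3)cc2)ccn1` has not yet been measured. It differs from compound 1 in one place: hydrogen in place of methoxy on an aromatic carbon. Among the measured compounds shown here, no measured pair in the set shows the same change, so its size rests on expectation alone. The expected step of a 1.5-fold higher number from compound 1 to compound 4 (0.19 log units; within the scatter) is modest, pointing, if anywhere, toward a weaker inhibitor, and may not exceed the usual scatter. Compound 4 is therefore estimated at 22000 nM in this assay, with a likely range from 7000 nM to 70000 nM.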

Compound 4, half-maximal inhibitory concentration: 7310 nM
The estimate for compound 4 lay 3.0-fold (0.48 log units) above the measured number; the measured number falls inside the stated range.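

In this assay, within the data shown here, 4-methoxyphenyl to phenyl gives a 1.9-fold lower number from compound 1 to compound 4 (0.29 log units; within the scatter), the first reading in this set of a change in one place only. The methoxy on this ring can therefore be replaced by hydrogen without a shift that rises above the usual scatter, so compound 1 and compound 4 cannot be told apart here, and a numeric result remains with the plain phenyl. Nothing shown gives a measured property that would explain this step.

From the compounds shown here alone, a single pair covers only hydrogen and methoxy at this carbon, so it remains open whether a dimethylamino group or a carboxylic acid there would move the number beyond the scatter. Going by these compounds, it also remains open whether the same change would read alike on a different core.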